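The source may hold more compounds than are shown below. What is called first, only, known or untested is meant among the compounds shown, and "the series" means these compounds.

Compound 3 `C#CCNC1CCc2c(SCc3cccc(C(F)(F)F)c3)cccc21` gives 4.7 nM in an assay on isolated protein for inhibition of Amine oxidase [flavin-containing] B (Homo sapiens) (on this read-out lower numbers stand for stronger inhibition and higher numbers for weaker inhibition), the lowest number of the three measured; compound 2 `C#CCNC1CCc2c(OCc3cccc(C(F)(F)F)c3)cccc21` gives 6410 nM and compound 1 `C#CCNC1CCc2c(SCc3cccc(Cl)c3)cccc21` gives 23300 nM. Compound 4 `C#CCNC1CCc2c(SCc3cccc(F)c3)cccc21` differs from compound 3 by fluoro in place of trifluoromethyl on an aromatic carbon. Going by the values given here, one measured step bears on the same aromatic carbon: a 5000-fold lower number from compound 1 to compound 3 (3.70 log units; beyond the scatter), a large drop when the group there was exchanged for trifluoromethyl. Moving away from trifluoromethyl again is therefore expected to raise the number markedly, although no fluoro analogue has been measured and the exact size cannot be read from the series. For compound 4 the expected step is a 640-fold higher number from compound 3 to compound 4 (2.81 log units; beyond the scatter). Compound 4 is estimated at 3000 nM, within 300 nM to 30000 nM.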

Compound 4, half-maximal inhibitory concentration: 1480 nM
Estimate against measurement, compound 4: 2.0-fold (0.31 log units) above; the measured number falls inside the stated range.
By their numbers in this assay, from the lowest: compound 3; then compound 4; then compound 2; then compound 1.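

Three groups can now be compared on this aromatic carbon in this assay: a 310-fold higher number from compound 3 to compound 4 (2.50 log units; beyond the scatter), and a 16-fold lower number from compound 1 to compound 4 (1.20 log units; beyond the scatter). Fluoro and chloro therefore both stay far from trifluoromethyl, yet they also differ from each other beyond the scatter, so the exchange of one halogen for another is not neutral here. The low number of compound 3 is thus tied to trifluoromethyl among the three groups read.

Nothing available explains these steps. As far as these compounds go, whether a nitrile or a methoxy group on this carbon would approach trifluoromethyl remains open.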